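Thiophene for Phenyl on a Hydroxyphenyl-Pyridine Core

The source may hold more compounds than are shown below. What is called first, only, known or untested is meant among the compounds shown, and "the series" means these compounds.

Of the compounds shown here, three built on a shared core have been measured in a functional assay on HeLa cells (Homo sapiens) for cytotoxicity, read by ELISA, with a stated time of 2 days; a lower number here means a stronger inhibitor, a higher number a weaker inhibitor. Compound 1 `Oc1cccc(-c2cc(-c3ccccc3)cc(-c3ccccc3)n2)c1` gives 16100 nM. Compound 2 `Oc1cccc(-c2cc(-c3ccccc3)cc(-c3cccs3)n2)c1` differs from it by one change, (thiophen-2-yl in place of phenyl on an aromatic carbon), and in this assay compound 2 gives 17000 nM; the step is a 1.1-fold higher number from compound 1 to compound 2 (0.02 log units; within the scatter). Compound 3 `Oc1cccc(-c2cc(-c3ccccc3)nc(-c3ccccc3)c2)c1` holds the same atoms as compound 1 joined differently; how the two cores differ is not broken down here. In this assay compound 3 gives 15100 nM, a number that sits within the scatter of both compound 1 and compound 2, so the three measured values show no separation from one another.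

Compound 4 `Oc1cccc(-c2cc(-c3ccccc3)nc(-c3cccs3)c2)c1` is not yet measured. It differs from compound 3 by thiophen-2-yl in place of phenyl on an aromatic carbon. This is the same change as that from compound 1 to compound 2, made at the same place on the core, and among the compounds shown it occurs twice in all. Because the earlier step, a 1.1-fold higher number from compound 1 to compound 2 (0.02 log units; within the scatter), stayed within the scatter, the step from compound 3 to compound 4 is expected to be similar in size, namely a 1.1-fold higher number from compound 3 to compound 4 (0.04 log units; within the scatter), resting on that single earlier pair. The expectation for compound 4 in this assay is therefore 16500 nM, with a range estimated from 8000 nM to 34000 nM.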

Compound 4, half-maximal inhibitory concentration: 15300 nM
The estimate for compound 4 lay 1.1-fold (0.03 log units) above the measured number; low and high end bracket the measured number.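

In this assay the new step is a 1.0-fold higher number from compound 3 to compound 4 (0.01 log units; within the scatter), and set beside the earlier step it gives the same picture on the second core: the same change on two cores in this assay, a 1.1-fold higher number (0.02 log units; within the scatter) from compound 1 to compound 2 and a 1.0-fold higher number (0.01 log units; within the scatter) from compound 3 to compound 4, 1.0-fold (0.02 log units) apart, within the scatter of two such steps. Within these four compounds, then, thiophen-2-yl in place of phenyl carries from the core of compound 1 to the core of compound 3 in a limited sense, with the step staying within the scatter on both. This does not show that the change would behave alike on any further core, and two steps that both stay within the scatter cannot show whether a step of visible size would carry across, so the agreement rests on one pair per core in a single assay.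

The compounds shown leave open whether an amine, a carboxylic acid or a longer chain on that aromatic carbon next to the ring nitrogen would give a number separated from the values seen so far, since only phenyl and thiophen-2-yl appear there. They also leave open what a methoxy group in place of the hydroxyl of the 3-hydroxyphenyl group would do, and whether the agreement between the two cores would hold in any other assay.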